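The compounds below may be only part of what the source reports. "The series", "measured", "known", "first", "only" and "open" are said of these compounds alone.

In a functional assay on MDA-MB-231 cells (Homo sapiens) for cytotoxicity, read by MTT assay, with a stated time of 72 h; on this read-out lower numbers stand for stronger inhibition and higher numbers for weaker inhibition:

- compound 1 `O=C(CN1CCN(c2nnc(Cc3ccncc3)c3ccccc23)CC1)Nc1cccc(Br)c1` gives 1.7 nM
- compound 2 `Cc1ccc(F)cc1NC(=O)CN1CCN(c2nnc(Cc3ccncc3)c3ccccc23)CC1` gives 6.4 nM

Compound 2, at 6.4 nM, holds the higher of the two numbers. Compound 3 `O=C(CN1CCN(c2nnc(Cc3ccncc3)c3ccccc23)CC1)Nc1ccc(F)c(F)c1` brings (3,4-difluorophenyl in place of 5-fluoro-2-methylphenyl on an amide-type nitrogen), with 3,4-difluorophenyl in place of 5-fluoro-2-methylphenyl on an amide-type nitrogen. Among the measured compounds shown here, one measured step bears on this place: a 3.8-fold higher number from compound 1 to compound 2 (0.58 log units; beyond the scatter), a modest change. With a single step as guide, only a slight lean toward a lower number is expected, and no shift beyond the scatter. The estimated step is a 1.6-fold lower number from compound 2 to compound 3 (0.20 log units; within the scatter). Compound 3 is expected at 4 nM, with an estimated range of 1.2 nM to 14 nM.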

Compound 3, half-maximal inhibitory concentration: 0.84 nM
Estimate against measurement, compound 3: 4.8-fold (0.68 log units) above; the whole stated range lies above it.
By their numbers in this assay, from the lowest: compound 3; then compound 1; then compound 2.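

In this assay, among the compounds shown here, the aryl group on the amide-type nitrogen has more influence than the single earlier step showed: 3,4-difluorophenyl in place of 5-fluoro-2-methylphenyl gives a clear drop (a 7.6-fold lower number from compound 2 to compound 3 (0.88 log units; beyond the scatter)), and in place of 3-bromophenyl a smaller one (a 2.0-fold lower number from compound 1 to compound 3 (0.31 log units; beyond the scatter)). Bromine is therefore not needed here, and compound 3 holds the lowest number of the three. Nothing available explains these differences.

Still open, on these data alone, is how a methoxy group or an amine on this phenyl ring would read. A saturated cyclohexyl ring in place of the phenyl ring is equally untested here.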